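The source may hold more compounds than are shown below. What is called first, only, known or untested is meant among the compounds shown, and "the series" means these compounds.

Measured in a functional assay on A2780 cells (Homo sapiens) for antiproliferative activity, read by MTT assay, with a stated time of 48 h; a higher number here means a weaker inhibitor, a lower number a stronger inhibitor:
- compound 1 `C=C(c1ccc(OC)cc1NC(=O)CO)c1ccc(OC)c2c1OC(C)(C)C=C2`: 40 nM
- compound 2 `C=C(c1cc(OC)c(OC)c(OC)c1)c1ccc(OC)c(O)c1NC(C)=O`: 170 nM
- compound 3 `C=C(c1cc(OC)c(OC)c(OC)c1)c1ccc(OC)c(O)c1NC(=O)COC`: 450 nM

Among these three, compound 3 has the highest number at 450 nM, making it the weakest inhibitor of the set. Compound 4 `C=C(c1cc(OC)c(OC)c(OC)c1)c1ccc(OC)c(O)c1NC(=O)COCC` has not yet been measured. It differs from compound 3 by methyl in place of hydrogen on a saturated chain carbon bound to an oxygen on a saturated carbon, which turns methoxy into ethoxy.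

Within the data shown here, only one measured step bears on this change, a 2.6-fold higher number from compound 2 to compound 3 (0.42 log units; beyond the scatter). That step placed methoxy in place of hydrogen on a saturated chain carbon bound to a carbonyl carbon, so it is a different change, though it involves the same methoxymethyl group. It was modest and pointed towards weaker inhibition. Among the measured compounds shown here, no measured pair shows the methyl change itself, and compound 1 differs from compound 3 in more than one place, so it offers no direct guide. A small shift in the same direction therefore seems the most reasonable expectation, and it may not clear the scatter. The expected step is a 1.3-fold higher number from compound 3 to compound 4 (0.12 log units; within the scatter). For compound 4 the estimated value is 600 nM, with an expected range of 250 nM to 1400 nM.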

Compound 4, half-maximal inhibitory concentration: 1230 nM
Beside the measured number, compound 4's estimate is 2.1-fold (0.31 log units) below it; the measured number falls inside the stated range.
By their numbers in this assay, from the lowest: compound 1; then compound 2; then compound 3; then compound 4.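

In this assay, methyl in place of hydrogen on a saturated chain carbon bound to an oxygen, which turns methoxy into ethoxy, gives a 2.7-fold higher number from compound 3 to compound 4 (0.44 log units; beyond the scatter), showing that this outer end of the chain still affects the number. Ethoxy in place of hydrogen on the saturated chain carbon bound to a carbonyl carbon gives a 7.2-fold higher number from compound 2 to compound 4 (0.86 log units; beyond the scatter), so the three compounds sharing this core, from hydrogen through methoxy to ethoxy, move towards weaker inhibition at each step, and each single step lies beyond the scatter. Nothing available accounts for this trend.

The compounds shown leave open whether the trend continues with a longer chain such as propoxy, or whether an amine such as dimethylamino at the same place would follow it. Going by these compounds, compound 1 carries a hydroxy group on this chain but differs from the others in more than one place, so the effect of that group on the core of compound 3 also remains open.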